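Carbamoyl for bromo on the benzyl ring

The source may hold more compounds than are shown below. What is called first, only, known or untested is meant among the compounds shown, and "the series" means these compounds.

Three compounds have numbers in a functional assay for agonist activity at Free fatty acid receptor 1 (Homo sapiens); a higher number here means that more compound is needed for the effect, a lower number that less compound is needed. Compound 2 `O=C(O)CCc1ccc(NCc2cccc(Br)c2)cc1` gives 794 nM, the lowest of the three. Compound 1 `O=C(O)CCCc1ccc(NCc2ccc(-c3ccccc3)cc2)cc1` gives 1580 nM, which lies within the scatter of compound 2, so no order between the two can be read. Compound 3 `O=C(O)CCc1ccc(NCc2ccccc2Cl)cc1` gives 3980 nM, a gap from compound 2 that lies beyond the scatter. Compound 4 `NC(=O)c1cccc(CNc2ccc(CCC(=O)O)cc2)c1` is not yet measured in this assay. It differs from compound 2 by carbamoyl in place of bromo on an aromatic carbon, meta to a large group. Among the measured compounds shown here, no measured pair shows this change, so the step has no precedent here. The step from compound 2 to compound 4 is expected to run toward a higher number, a 3.1-fold higher number from compound 2 to compound 4 (0.50 log units; beyond the scatter), somewhat beyond the scatter. Compound 4 is expected at 2500 nM, within a range from 800 nM to 8000 nM.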

Compound 4, half-maximal effective concentration: < 31700 nM
Compound 4: no number, only a limit; the forecaster's own chance of this, stated with the estimate: 10%; the middle value lies beyond the limit too.
By their numbers in this assay, from the lowest: compounds 2 and 1 (each within the scatter of the next); then compound 3.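

Compound 4 gives only a limit in this assay, < 31700 nM, so the step from compound 2 cannot be read. How far carbamoyl in place of bromo moves the number stays open among the compounds shown.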